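Chain extension at the acidic end: compound 3 to compound 4

The source may report more compounds than this note shows. Statements on the series, on what has been measured and on what is new or still open speak of the compounds shown alone.

Series notes. In an assay on a protein complex for binding affinity to integrin alpha-5/beta-1 (Homo sapiens), with a stated time of 30 min (a higher number here means a weaker inhibitor, a lower number a stronger inhibitor), compound 1, `Cc1ccccc1NC(=O)N1CCC[C@H]1C(=O)O`, gives 136 nM. Compound 2, `Cc1ccccc1C(=O)N1C(=O)C[C@H]1C(=O)O`, gives 59.3 nM in this assay. Compound 3, `Cc1ccccc1NC(=O)NCC(=O)O`, returns only a limit in this assay, > 1000 nM, and no number. Of the three values shown, compound 3 is the one sitting at the limit of > 1000 nM in this assay, at which 1 of the 3 values shown sits, so its position relative to compound 1 and compound 2 is known only as the wrong side of that limit.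

Compound 4, `Cc1ccccc1NC(=O)NCCC(=O)O`, has not been measured in this assay. The difference from compound 3 is carboxymethyl in place of carboxy on a saturated chain carbon bound to an amide-type nitrogen, which leaves the ring-free chain of compound 3 otherwise as it is. Within the data shown here, no measured pair in the set shows this kind of change, so there is no step to lean on. The expectation is that the step from compound 3 to compound 4 in this assay is small in either direction, not beyond the scatter, and most likely compound 4 again returns only a limit, with the estimate a step that the limit leaves unreadable from compound 3 to compound 4.

For compound 4 the expected value in this assay is 2500 nM, with a range from 600 nM to 10000 nM.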

Compound 4, half-maximal inhibitory concentration: > 1000 nM
Compound 4 was reported as a limit; the forecaster's own chance of this, stated with the estimate: 65%; the middle value lies beyond the limit too.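

Compound 3 and compound 4 both return only a limit in this assay, so no step can be read between them: the limit of > 1000 nM in this assay, at which 2 of the 4 values shown sit.

The compounds shown leave open whether carboxymethyl in place of carboxy on a saturated chain carbon bound to an amide-type nitrogen shifts the value in this assay at all, and in which direction.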